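A few compounds are considered here, and "the series" means these few. Any claim that something is new, unique, unknown or untested is made for them only; others in the source may bear on it.

Compound 1 `CCCCCn1c(-c2ccco2)nc2c(NCCOC)ccnc21`: in an assay on isolated protein for inhibition of high affinity 3',5'-cyclic-AMP phosphodiesterase 7A (Homo sapiens), read by cAMP accumulation, with a stated time of 20 min (on this read-out higher numbers stand for weaker inhibition and lower numbers for stronger inhibition), compound 1 gives > 200000 nM, which is a limit of the assay and not a number.
Compound 2 `COCCNc1ccnc2c1nc(-c1ccco1)n2C1CCCC1`: in this assay compound 2 gives 119000 nM.

Compound 1 stands at the limit of this assay, so only a floor is known for it (the limit of > 200000 nM in this assay, at which 1 of the 2 values shown sits). Going by the values given here, the single measured step, an at least 1.6-fold lower number from compound 1 to compound 2 (0.22 log units; that floor lies within the scatter), replaces the group on the aromatic nitrogen and leaves the side chain untouched; its floor lies within the scatter anyway, so it says little about the change followed here. Compound 3 `CCCCCn1c(-c2ccco2)nc2c(NCCCO)ccnc21` differs from compound 1 by hydroxymethyl in place of methoxy on a saturated chain carbon, two bonds along the chain from a nitrogen on an aromatic ring. Among the compounds with values here, no measured step covers this change, and nothing in the data points the expectation up or down beyond the scatter. Compound 3 is therefore expected to sit close to where compound 1 sits, with a step of a number no higher from compound 1 to compound 3 (the limit leaves the size open) that is essentially none. The estimate for compound 3 is 200000 nM, in the range from 80000 nM to 500000 nM, with a real chance that only a limit is reported again.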

Compound 3, half-maximal inhibitory concentration: 63600 nM
Compound 3: the middle estimate sits 3.1-fold (0.50 log units) above what was measured; the measured number lies below the stated range.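

In this assay, hydroxymethyl in place of methoxy on this side chain gives an at least 3.1-fold lower number from compound 1 to compound 3 (0.49 log units; beyond the scatter), so this position responds to the change by more than the scatter, which the earlier step at the aromatic nitrogen could not show. The two compounds have the same atoms, joined differently, and hydroxymethyl counts one hydrogen-bond donor where methoxy counts none, although a single pair cannot tell whether that donor or the rearranged chain matters. The step is only a floor because compound 1 carries a limit and not a number: the limit of > 200000 nM in this assay, at which 1 of the 3 values shown sits.

As far as these compounds go, it remains open whether an amine or a carboxylic acid in place of hydroxymethyl, or a longer chain, would give lower numbers still. Also open, from the compounds shown here alone, is whether the same change would carry over with cyclopentyl in place of pentyl on the aromatic nitrogen.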